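The compounds below may be only part of what the source reports. "The series", "measured", "known", "first", "only" and "open" are said of these compounds alone.

Working notes on the series. Compound 1 `O=C(Nc1ccc(-n2ccc3c(NC(=O)c4ccccc4)ncnc32)cc1)c1ccc(Cl)c(Cl)c1` carries a benzamido group on the shared core and an amide link to the outer ring; compound 2 `Nc1ncnc2c1ccn2-c1ccc(NC(=O)Nc2ccc(Cl)c(C(F)(F)F)c2)cc1` and compound 3 `Nc1ncnc2c1ccn2-c1ccc(NC(=O)Nc2cc(C(F)(F)F)cc(C(F)(F)F)c2)cc1` keep a free amino group on that core and join the outer rings through a urea. In an ADME assay on HS27 cells (Homo sapiens) for antiproliferative activity, read by MTT assay, with a stated time of 24 h (a higher number here means a weaker inhibitor, a lower number a stronger inhibitor), compound 1 gives 5000 nM. Compound 2 reaches only the limit of this assay, > 10000 nM, a limit and not a number. Compound 3 gives 9500 nM in this assay, the higher of the two numbers obtained; the nearest is compound 1, and that gap lies within the scatter, so no order between compound 1 and compound 3 is claimed. One of the three results sits at the limit, (the limit of > 10000 nM in this assay, at which 1 of the 3 values shown sits).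

Compound 4 `O=C(Nc1ccc(-n2ccc3c(NC(=O)c4ccccc4)ncnc32)cc1)Nc1cc(C(F)(F)F)cc(C(F)(F)F)c1` has not yet been measured. It differs from compound 3 by benzoyl in place of hydrogen on a nitrogen on an aromatic ring, amino to benzamido. Among the compounds with values here, no measured pair isolates this change, so its size is not known from the data. Compound 1 holds the same benzamido group and gives 5000 nM, a weak result like the others. The step from compound 3 to compound 4 in this assay is therefore expected to be a 1.5-fold lower number from compound 3 to compound 4 (0.16 log units; within the scatter), none beyond the scatter. Compound 4 is expected near 6500 nM, with a range from 2500 nM to 15000 nM.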

Compound 4, half-maximal inhibitory concentration: > 10000 nM
Compound 4: no number, only a limit; the forecaster's own chance of this, stated with the estimate: 25%; middle value at least 1.5-fold (0.18 log units) from the limit.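

Within the data shown here, the pair of compound 3 and compound 4 is the first to isolate benzoyl in place of hydrogen on a nitrogen on an aromatic ring, and in this assay it reads as an at least 1.0-fold higher number from compound 3 to compound 4 (0.02 log units; that floor lies within the scatter). This step is a floor and not a size: the result for compound 4 is a limit, so the change from amino to benzamido at this position is not shown to give a lower number in this series. Any further step that ends at this limit can likewise be read only as a floor: the limit of > 10000 nM in this assay, at which 2 of the 4 values shown sit.

Going by these compounds, it remains open whether a small acyl group such as acetyl, or a longer chain ending in a carboxylic acid or an amine, on this same nitrogen would give a number that can be read against compound 3. The compounds shown also hold no pair differing only in the link to the outer ring, so the urea and the amide cannot be compared directly.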